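Methoxy for hydroxy on the chlorophenyl arm

The source may report more compounds than this note shows. Statements on the series, on what has been measured and on what is new or still open speak of the compounds shown alone.

Three compounds have been run in a functional assay on NCI-H322M cells (Homo sapiens) for inhibition, read by sulforhodamine B assay, with a stated time of 48 h, tested at 10 uM; a lower number here means a stronger effect, a higher number a weaker effect of the compound at the concentration tested. Compound 1 `O=C(Nc1cccc(-n2cc(-c3ccncc3)c(-c3cc(O)cc(Cl)c3)n2)c1)Nc1ccc(Cl)c(Cl)c1` gives 19.5%, compound 2 `COc1cc(Cl)cc(-c2nn(-c3cccc(NC(=O)c4cccc(C(F)(F)F)c4)c3)cc2-c2ccncc2)c1` gives 78.6%, and compound 3 `O=C(Nc1cccc(-n2cc(-c3ccncc3)c(-c3cc(O)cc(Cl)c3)n2)c1)c1cc(C(F)(F)F)cc(C(F)(F)F)c1` gives 74.1%. On these numbers compound 3 stands second highest of the three; its nearest neighbour is compound 2, within the scatter of it, while compound 1 lies far lower, beyond the scatter. Compound 4 `COc1cc(Cl)cc(-c2nn(-c3cccc(NC(=O)c4cc(C(F)(F)F)cc(C(F)(F)F)c4)c3)cc2-c2ccncc2)c1` differs from compound 3 in one place: methyl in place of hydrogen on an oxygen on an aromatic ring. Among the measured compounds shown here, no measured pair shows this change on its own. The expected step in this assay is a number 1.9 percentage points higher from compound 3 to compound 4 (within the scatter), nothing beyond the scatter, because compound 2, which carries the methoxy, gives 78.6%. Compound 4 is estimated at 76%, within 60% to 90%.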

Compound 4, a percentage reported as activity, at one concentration (the size of the read-out at that concentration, not a potency): 80.3%
For compound 4 the middle estimate is 4.3 percentage points below the measured one, within the range that was stated.
By their numbers in this assay, from the lowest: compound 1; then compounds 3, 2 and 4 (each within the scatter of the next).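

In this assay the change can now be read on its own: hydroxy to methoxy gives a number 6.2 percentage points higher from compound 3 to compound 4 (within the scatter) and so does not separate the two compounds at this oxygen. Trifluoromethyl in place of hydrogen on an aromatic carbon gives a number 1.7 percentage points higher from compound 2 to compound 4 (within the scatter) with the methoxy in place, so that change does not separate its pair either. Nothing available explains either step.

On these data alone, whether an amine or an ethoxy group at this position would behave the same remains open. So does whether hydroxy to methoxy would give a similar step on compound 1 19.5% in its much lower range.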